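Two Configuration Changes Starting From Compound 2

This account rests on a few compounds, and the source may have more. Where it says the series, first, only, none or still open, it means among the compounds named here.

For the measured compounds named here, in a functional assay on A549 cells (Homo sapiens) for cytotoxicity (a higher number here means that more compound is needed for the effect, a lower number that less compound is needed), compound 2 `CC/C=C\C/C=C\C/C=C\C/C=C\C[C@]1(OC)C=CC(=O)O1` gives 32.1 ug/mL and stands highest of the two numbers so far, while compound 1 `CCCCC/C=C\C/C=C\C/C=C\C[C@@]1(OC)C=CC(=O)O1` gives 10.1 ug/mL and so needs less compound for the same effect. Compound 3 `CC/C=C/C/C=C\C/C=C\C/C=C\C[C@@]1(OC)C=CC(=O)O1` has the same atoms and bonds as compound 2 and differs only in configuration as drawn, with the two compounds have the same atoms and bonds and differ only in configuration as drawn: 2 of 5 stereo elements differ; a stereocentre at a saturated ring carbon is drawn R in compound 2 and S in compound 3; a double bond is drawn Z in compound 2 and E in compound 3 as the whole change. Going by the values given here, no measured pair shows what such a change does. In this assay the expected change is a 1.3-fold lower number from compound 2 to compound 3 (0.11 log units; within the scatter) and small, toward a lower number and within the scatter. The estimate for compound 3 is 25 ug/mL with 10 ug/mL to 60 ug/mL as its expected range.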

Compound 3, concentration for half-maximal effect: > 30 ug/mL
Compound 3: only a limit was reported; the forecaster's own chance of this, stated with the estimate: 5%; middle value at least 1.2-fold (0.07 log units) from the limit.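

Compound 3 gives > 30 ug/mL in this assay, which is a limit of the assay and not a number. The step from compound 2 therefore cannot be read: the limit of > 30 ug/mL in this assay, at which 1 of the 3 values shown sits. For the compounds shown here, putting but-1-en-1-yl in place of butyl on a saturated chain carbon bound to a double-bonded chain carbon gives an at least 2.9-fold higher number from compound 1 to compound 3 (0.47 log units; beyond the scatter), the first readable step in this set.

From the compounds shown here alone, what the stereocentre at the saturated ring carbon and the double bond each do alone stays open, since the two change together: the fact that compounds 2 and 3 differ only in the configuration as drawn. Also open, going by these compounds, is how a chain ending in an amine or a carboxylic acid would behave in this assay.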